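Trimethoxyphenyl pyrazolyl enones: growth inhibition working notes

This account rests on a few compounds, and the source may have more. Where it says the series, first, only, none or still open, it means among the compounds named here.

Compound 1 `COc1cc(-c2cc(/C=C/C(=O)c3ccc(Cl)c(Cl)c3)[nH]n2)cc(OC)c1OC`: 5890 nM
Compound 2 `COc1ccc(C(=O)/C=C/c2cc(-c3cc(OC)c(OC)c(OC)c3)n[nH]2)cc1OC`: 1480 nM

Among the measured compounds shown here, in a functional assay on A498 cells (Homo sapiens) for inhibition, read by sulforhodamine B assay, with a stated time of 48 h (on this read-out lower numbers stand for stronger inhibition of growth and higher numbers for weaker inhibition of growth), compound 2 gives 1480 nM, the lowest of the two numbers measured so far; compound 1 gives 5890 nM. For the measured compounds named here, the single measured step, a 4.0-fold lower number from compound 1 to compound 2 (0.60 log units; beyond the scatter), exchanges the whole substituent pattern of the ring on the carbonyl carbon. Compound 3 `COc1cc(C(=O)/C=C/c2cc(-c3cc(OC)c(OC)c(OC)c3)n[nH]2)cc(OC)c1OC` differs from compound 2 by methoxy in place of hydrogen on an aromatic carbon. Going by the values given here, no measured step covers adding one methoxy to that ring, so no direction can be read from the series. Compound 3 is expected to stay within the scatter of compound 2, a step of a 1.2-fold lower number from compound 2 to compound 3 (0.09 log units; within the scatter). Compound 3 is estimated at 1200 nM, range 400 nM to 3600 nM.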

Compound 3, concentration for 50% growth inhibition: 1610 nM
The estimate for compound 3 lay 1.3-fold (0.13 log units) below the measured number, within the range that was stated.
By their numbers in this assay, from the lowest: compounds 2 and 3 (each within the scatter of the next); then compound 1.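

In this assay, methoxy in place of hydrogen on an aromatic carbon, ortho to a methoxy group, gives a 1.1-fold higher number from compound 2 to compound 3 (0.04 log units; within the scatter). This position on the ring on the carbonyl carbon therefore accepts one more methoxy without a step beyond the scatter, something the earlier step could not show, as it exchanged the whole substituent pattern. No measurement available here explains this result. On these data alone, it remains open how an amine or a carboxylic acid would read at this position. As far as these compounds go, a longer chain, such as ethoxy, in place of this methoxy also remains open.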